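Methoxy on the second aryl ring: an expected small step

The compounds below may be only part of what the source reports. "The series", "measured", "known", "first", "only" and "open" are said of these compounds alone.

Measured compounds:
Compound 1 `O=C1N=C(N2N=C(c3ccccc3)CC2c2ccccc2O)S/C1=C1/C(=O)Nc2ccccc21` — 2410 nM
Compound 2 `COc1ccc(C2CC(c3ccccc3)=NN2C2=NC(=O)/C(=C3\C(=O)Nc4ccccc43)S2)cc1` — 2300 nM
Compound 3 `COc1ccc(C2CC(c3ccccc3)=NN2C2=NC(=O)/C(=C3\C(=O)Nc4ccc(Br)cc43)S2)cc1` — 230 nM

In a functional assay on cells (Cancer cell lines, Homo sapiens) for cytotoxicity, read by sulforhodamine B assay, with a stated time of 48 h (on this read-out higher numbers stand for weaker inhibition of growth and lower numbers for stronger inhibition of growth), compound 2 gives 2300 nM, the second highest of the three numbers. Its nearest neighbour is compound 1, and the change a 1.0-fold lower number from compound 1 to compound 2 (0.02 log units; within the scatter) is within the scatter. Compound 3 is furthest away, with a 10-fold lower number from compound 2 to compound 3 (1.00 log units; beyond the scatter).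

Compound 4 `COc1ccc(C2=NN(C3=NC(=O)/C(=C4\C(=O)Nc5ccccc54)S3)C(c3ccc(OC)cc3)C2)cc1` differs from compound 2 by methoxy in place of hydrogen on an aromatic carbon. For the measured compounds named here, no measured step touches this ring. Going by the values given here, the closest comparison is the swap of aryl groups on the saturated ring carbon, a 1.0-fold lower number from compound 1 to compound 2 (0.02 log units; within the scatter), which changed nothing beyond the scatter; the only large step, a 10-fold lower number from compound 2 to compound 3 (1.00 log units; beyond the scatter), concerns bromo on a different ring and does not bear on this change. A step of no size beyond the scatter is therefore expected for no change at the digits printed from compound 2 to compound 4 (within the scatter). Compound 4 is estimated at 2300 nM, with a range from 1000 nM to 5500 nM.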

Compound 4, concentration for 50% growth inhibition: 92200 nM
For compound 4 the middle estimate is 40-fold (1.60 log units) below the measured one; the whole stated range lies below it.
By their numbers in this assay, from the lowest: compound 3; then compounds 2 and 1 (each within the scatter of the next); then compound 4.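

In this assay, the change from phenyl to 4-methoxyphenyl gives a 40-fold higher number from compound 2 to compound 4 (1.60 log units; beyond the scatter), a large step that runs in the opposite direction to a 10-fold lower number from compound 2 to compound 3 (1.00 log units; beyond the scatter). For the compounds shown here, this aromatic ring, which no earlier step had touched, therefore proves highly sensitive to a single methoxy group para to a large group. The swap on the saturated ring carbon, a 1.0-fold lower number from compound 1 to compound 2 (0.02 log units; within the scatter), stayed within the scatter, so that result does not carry over to this ring.

The compounds shown leave open whether a fluoro or hydroxyl group in the same place would also weaken growth inhibition, and whether the bromo group of compound 3 would offset the methoxy effect. Nothing available here accounts for the size of this step.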